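Moving the Methoxy Group on the Aryl Ring

The source may hold more compounds than are shown below. What is called first, only, known or untested is meant among the compounds shown, and "the series" means these compounds.

Of the compounds shown here, three have been measured in a functional assay on A549 cells (Homo sapiens) for antiproliferative activity, read by MTT assay, with a stated time of 48 h; on this read-out higher numbers stand for weaker inhibition and lower numbers for stronger inhibition. There, compound 1 `CCn1cc(-c2cccc(OC)c2)c(=O)c2cc(F)c(N3CCNCC3)cc21` gives 800 nM and compound 2 `O=c1c(-c2ccc(Cl)cc2)cn(C2CC2)c2cc(N3CCNCC3)c(F)cc12` gives 650 nM, while compound 3 `COc1ccc(-c2cn(C3CC3)c3cc(N4CCNCC4)c(F)cc3c2=O)cc1` gives 1870 nM, the highest of the three numbers. Compound 4 `COc1cccc(-c2cn(C3CC3)c3cc(N4CCNCC4)c(F)cc3c2=O)c1` has not yet been measured. It keeps the core of compound 3 and carries 3-methoxyphenyl in place of 4-methoxyphenyl on an aromatic carbon.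

Within the data shown here, only one measured step bears directly on this part of the molecule. Exchanging chloro for methoxy gives a 2.9-fold higher number from compound 2 to compound 3 (0.46 log units; beyond the scatter), so a change on this aryl group can shift the number modestly. Among the measured compounds shown here, no measured pair isolates the swap between the two methoxyphenyl groups on a single core. The nearest evidence is compound 1, which already bears 3-methoxyphenyl, though with ethyl instead of cyclopropyl, and gives 800 nM. A modest step towards stronger inhibition in this assay is therefore expected, with real uncertainty about its size. The expected change is a 2.1-fold lower number from compound 3 to compound 4 (0.32 log units; beyond the scatter). For compound 4 the estimated value is 900 nM, with an expected range from 400 nM to 2000 nM.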

Compound 4, half-maximal inhibitory concentration: 120 nM
The estimate for compound 4 lay 7.5-fold (0.88 log units) above the measured number; measured number below the stated range.
By their numbers in this assay, from the lowest: compound 4; then compounds 2 and 1 (each within the scatter of the next); then compound 3.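

In this assay, among these compounds, the methoxy group's place on the aryl ring proves decisive: with the same atoms joined differently, 3-methoxyphenyl in place of 4-methoxyphenyl gives a 16-fold lower number from compound 3 to compound 4 (1.19 log units; beyond the scatter) and this step is far larger than a 2.9-fold higher number from compound 2 to compound 3 (0.46 log units; beyond the scatter) the only earlier step at this position. The new group also outperforms the earlier halogen-bearing aryl group, with a 5.4-fold lower number from compound 2 to compound 4 (0.73 log units; beyond the scatter) showing that a methoxy group at this position is not unfavourable in itself and that its effect depends on where it sits on the ring. With 3-methoxyphenyl held fixed, cyclopropyl in place of ethyl on the ring nitrogen gives a 6.7-fold lower number from compound 1 to compound 4 (0.82 log units; beyond the scatter) so the group on that nitrogen also matters, although nothing available explains either shift.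

The compounds shown leave open whether 3-chlorophenyl would follow the same trend as 3-methoxyphenyl, and whether a hydroxyl group or an amine at that place on the aryl ring would keep the number as low. Going by these compounds, it also remains open whether the gain from moving the methoxy group would persist with ethyl on the ring nitrogen.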